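The source may report more compounds than this note shows. Statements on the series, on what has been measured and on what is new or still open speak of the compounds shown alone.

Measured so far:
compound 1, `COc1ccc(/C=N/NC(=O)c2ccc(O[C@@H]3O[C@H](CO)[C@@H](O)[C@H](O)[C@H]3O)cc2)cc1`: 11.3%
compound 2, `O=C(N/N=C/c1ccc([N+](=O)[O-])cc1)c1ccc(O[C@@H]2O[C@H](CO)[C@@H](O)[C@H](O)[C@H]2O)cc1`: 7.12%

Both were run in a functional assay on MDA-MB-231 cells (Homo sapiens) for inhibition, read by MTT assay, with a stated time of 24 h, tested at 100 uM; a lower number here means less inhibition, a higher number more inhibition at the concentration tested (going by the name of the read-out). Compound 2 has the lowest of the two numbers, with compound 1 nearest at a number 4.2 percentage points lower from compound 1 to compound 2 (within the scatter), a step within the scatter, so no order between the two can be read. Among the compounds with values here, the only measured change, nitro in place of methoxy on an aromatic carbon, left the read-out essentially where it was.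

Compound 3, `CCCCC/C=N/NC(=O)c1ccc(O[C@@H]2O[C@H](CO)[C@@H](O)[C@H](O)[C@H]2O)cc1`, is not yet measured in this assay. It differs from compound 2 by pentyl in place of 4-nitrophenyl on a carbon with a double bond to nitrogen. Within the data shown here, this exchange removes the aromatic ring that the one measured step only decorated, so that step bears on it indirectly at most; what it does show is that the read-out stayed low across both measured compounds. With no measured step beyond the scatter, the working expectation is a step of no more than scatter size. Compound 3 is expected to give 9%, range 0% to 25%. The expected step is a number 1.9 percentage points higher from compound 2 to compound 3 (within the scatter).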

Compound 3, a percentage reported as inhibition, at one concentration (the size of the read-out at that concentration, not a potency): 11%
For compound 3 the middle estimate is 2 percentage points below the measured one; the measured number falls inside the stated range.
By their numbers in this assay, from the lowest: compounds 2, 3 and 1 (each within the scatter of the next).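

In this assay, pentyl in place of 4-nitrophenyl on a carbon with a double bond to nitrogen gives a number 3.9 percentage points higher from compound 2 to compound 3 (within the scatter), and pentyl in place of 4-methoxyphenyl at the same place gives a number 0.3 percentage points lower from compound 1 to compound 3 (within the scatter). The earlier pair changed only the group carried on the aromatic ring, whereas these two steps remove the ring altogether, leaving a chain with no ring and no hydrogen-bond acceptors in its place. Among these three compounds, then, even this larger exchange at this position produces no step beyond the scatter, so the read-out at the single concentration tested does not depend on the aromatic ring being present.

Still open, on these data alone, is whether any group at this position can move the read-out beyond the scatter, for instance a longer chain such as decyl, a primary amine or a carboxylic acid. Also open, as far as these compounds go, is how far the rest of the shared core contributes to the read-out, since all three compounds carry it unchanged. No measurement is available that would explain why these exchanges leave the read-out within the scatter.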